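This account rests on a few compounds, and the source may have more. Where it says the series, first, only, none or still open, it means among the compounds named here.

Three compounds have been measured in a functional assay on PC-3 cells (Homo sapiens) for cytotoxicity, read by sulforhodamine B assay, with a stated time of 48 h; a higher number here means a weaker inhibitor, a lower number a stronger inhibitor:

compound 1 `CC(=O)N1N=C(c2cccc3ccccc23)CC1c1ccco1` gives 18000 nM;
compound 2 `COc1ccc(C2CC(c3cccc4ccccc34)=NN2C(C)=O)cc1` gives 4930 nM;
compound 3 `O=CCN1N=C(c2ccc3ccccc3c2)CC1c1ccco1` gives 23000 nM.

Compound 1 and compound 2 share a core and differ in one place, (4-methoxyphenyl in place of furan-2-yl on a saturated ring carbon). That change produced a 3.7-fold lower number from compound 1 to compound 2 (0.56 log units; beyond the scatter), a modest step but one that lies beyond the usual scatter of this assay.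

Compound 3 is built from the same atoms as compound 1, joined differently; how the two cores differ is not broken down here. In this assay the values of compound 3 and compound 1 lie within the scatter of each other, so no order between them can be claimed, while compound 2 sits clearly lower than both.

Compound 4 `COc1ccc(C2CC(c3ccc4ccccc4c3)=NN2CC=O)cc1` has not yet been measured. It stands to compound 3 as compound 2 stands to compound 1, through (4-methoxyphenyl in place of furan-2-yl on a saturated ring carbon). This is the same kind of change as that from compound 1 to compound 2, though not the same: around the place, the ring atom carries a formylmethyl group in the pair of compound 3 and compound 4, and an acetyl group in the pair of compound 1 and compound 2.

Because of a 3.7-fold lower number from compound 1 to compound 2 (0.56 log units; beyond the scatter), a step of similar size is expected for a 3.7-fold lower number from compound 3 to compound 4 (0.57 log units; beyond the scatter) in this assay. On that basis compound 4 is estimated at 6200 nM in this assay.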

Compound 4, half-maximal inhibitory concentration: 4530 nM
Compound 4: the middle estimate sits 1.4-fold (0.14 log units) above what was measured; low and high end bracket the measured number.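

In this assay, putting 4-methoxyphenyl in place of furan-2-yl on the saturated ring carbon again gave a lower number, with a 5.1-fold lower number from compound 3 to compound 4 (0.71 log units; beyond the scatter). The change therefore carried over from the core of compound 1, which has the acetyl group, to the core of compound 3, which has the formylmethyl group, and no difference in the size of the two steps can be claimed: the same change on two cores in this assay, a 3.7-fold lower number (0.56 log units; beyond the scatter) from compound 1 to compound 2 and a 5.1-fold lower number (0.71 log units; beyond the scatter) from compound 3 to compound 4, 1.4-fold (0.14 log units) apart, within the scatter of two such steps. This shows that the step held on these two cores, for this one pair of groups and in this one cell assay, but it does not explain why the number falls or show that the step would hold on any other core.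

The compounds shown leave open whether other groups on that saturated ring carbon, such as an unsubstituted phenyl, a 4-hydroxyphenyl or a pyridine ring, would give a step of similar size or a different one. They also leave open whether the same step would survive if the acetyl or formylmethyl group gave way to a longer chain, an amine or a carboxylic acid.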